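Swapping the benzylamino of compound 1 for an azepane ring

This account rests on a few compounds, and the source may have more. Where it says the series, first, only, none or still open, it means among the compounds named here.

Among the measured compounds shown here, compound 1 `CC(C(=O)NCc1ccc(C(F)(F)F)nc1NCc1ccccc1)c1ccc(NS(C)(=O)=O)c(F)c1` is one of three compounds measured in a functional assay on CHO-K1 cells for antagonist activity at transient receptor potential cation channel subfamily V member 1 (Homo sapiens), read by FLIPR (a higher number here means a weaker inhibitor, a lower number a stronger inhibitor), where compound 1 gives 203 nM. This is the highest of the three numbers. Compound 2 `C[C@H](C(=O)NCc1ccc(C(F)(F)F)nc1N1CC[C@@H](OCc2ccccc2)C1)c1ccc(NS(C)(=O)=O)c(F)c1` gives 50 nM and compound 3 `CC(C(=O)NCc1ccc(C(F)(F)F)nc1N1CCC(OC(=O)C(C)(C)C)CC1)c1ccc(NS(C)(=O)=O)c(F)c1` gives 45.2 nM; both lie below compound 1 by more than the usual scatter, and both replace the benzylamino of compound 1 with a different group. Compound 4 `CC(C(=O)NCc1ccc(C(F)(F)F)nc1N1CCCCCC1)c1ccc(NS(C)(=O)=O)c(F)c1` differs from compound 1 in one place: azepan-1-yl in place of benzylamino on an aromatic carbon. Because compound 2 gives 50 nM and compound 3 gives 45.2 nM, a step downward toward a stronger inhibitor is expected; for compound 4 the estimated step is a 2.0-fold lower number from compound 1 to compound 4 (0.31 log units; beyond the scatter). The estimate for compound 4 in this assay is 100 nM, with a range from 30 nM to 350 nM.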

Compound 4, half-maximal inhibitory concentration: 25.1 nM
Compound 4: middle estimate off by 4.0-fold (0.60 log units), on the high side; the measured number lies below the stated range.
By their numbers in this assay, from the lowest: compounds 4, 3 and 2 (each within the scatter of the next); then compound 1.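

In this assay, the swap gives an 8.1-fold lower number from compound 1 to compound 4 (0.91 log units; beyond the scatter), so at this aromatic carbon next to the ring nitrogen, a stronger inhibitor needs neither the aromatic ring of benzylamino nor its hydrogen-bond donor. The seven-membered ring of compound 4 also carries no further group, yet its number lies within the scatter of that of compound 3, which has a substituted ring. Nothing shown explains the drop in number.

On these data alone, whether a plain piperidin-1-yl or pyrrolidin-1-yl ring, or an open-chain dimethylamino group, would do as well remains open.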